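Cytotoxicity series: vinyl in place of methylsulfonyl

The compounds below may be only part of what the source reports. "The series", "measured", "known", "first", "only" and "open" are said of these compounds alone.

Of the compounds shown here, three sharing one core have been read in an ADME assay on PC-3 cells (Homo sapiens) for cytotoxicity, read by WST assay, tested at 100 uM; on this read-out lower numbers stand for less inhibition and higher numbers for more inhibition at the one concentration tested (going by the name of the read-out). Compound 1 `COC(=O)c1cccc(C(=O)N2CCCC(C(=O)Nc3ccc(Cl)cc3)C2)c1` gives 0% in this assay. Compound 2 `CC(C)(C)CC(=O)Nc1cccc(C(=O)N2CCCC(C(=O)Nc3ccc(Cl)cc3)C2)c1` gives 0%, and the step of no change at the digits printed from compound 1 to compound 2 (within the scatter) shows the two as indistinguishable. Compound 3 `CS(=O)(=O)c1cccc(C(=O)N2CCCC(C(=O)Nc3ccc(Cl)cc3)C2)c1` gives 2% in this assay; the steps of a number 2 percentage points higher from compound 1 to compound 3 (within the scatter) and a number 2 percentage points higher from compound 2 to compound 3 (within the scatter) are both within the scatter, so compound 3 stands level with compound 1 and compound 2, and nothing in the set rises above the noise of the read-out.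

Compound 4 `C=Cc1cccc(C(=O)N2CCCC(C(=O)Nc3ccc(Cl)cc3)C2)c1` is the next point; its change from compound 3 is vinyl in place of methylsulfonyl on an aromatic carbon. Going by the values given here, none of the measured steps touches this exact exchange. What bears on it is the general picture: three different groups on the same aromatic carbon of the core, one of them the methylsulfonyl that now leaves, have all left the read-out flat, each step between them within the scatter. On that basis the step of no change at the digits printed from compound 3 to compound 4 (within the scatter) is expected to be no change beyond the scatter. For compound 4 the estimate in this assay is 2%, with a range from 0% to 12%, the upper end allowing only for ordinary scatter about a flat result.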

Compound 4, a percentage reported as inhibition, at one concentration (the size of the read-out at that concentration, not a potency): 0%
Estimate against measurement, compound 4: 2 percentage points above; measured number inside the range.
By their numbers in this assay, from the lowest: compounds 1, 2, 4 and 3 (each within the scatter of the next).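

Vinyl carries no hydrogen-bond acceptors and has fewer heavy atoms than the methylsulfonyl it replaces, yet in this assay the exchange gives the step of a number 2 percentage points lower from compound 3 to compound 4 (within the scatter). The aromatic carbon meta to a large group therefore now holds a plain two-carbon group, and this group gives a read-out that cannot be told apart from those of the larger groups: the steps are no change at the digits printed from compound 2 to compound 4 (within the scatter) and no change at the digits printed from compound 1 to compound 4 (within the scatter). Nothing in the data offers an explanation for the flat read-out across these four compounds.

Open, as far as these compounds go, is whether a carboxylic acid or an amine on this aromatic carbon would give a number beyond the scatter of the four seen so far. Also open, from the compounds shown here alone, is whether the flat result holds for changes elsewhere, for instance a group other than chloro on the anilide ring, as all four compounds share the rest of the core unchanged.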